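Methoxy to hydroxy: a small change to compound 3

A few compounds are considered here, and "the series" means these few. Any claim that something is new, unique, unknown or untested is made for them only; others in the source may bear on it.

In a functional assay on SW-620 cells (Homo sapiens) for cytotoxicity, read by MTT assay, with a stated time of 72 h (a lower number here means a stronger inhibitor, a higher number a weaker inhibitor), compound 1 `COc1cccc(/C=C2\CCC/C(=C\c3cccc(OC)c3OC)C2=O)c1` gives 7000 nM and compound 3 `COc1ccc(/C=C2\CCC/C(=C\c3cccc(OC)c3OC)C2=O)cc1OC` gives 6400 nM, two values that cannot be told apart. Compound 2 `COc1cccc(/C=C2\CCC/C(=C\c3ccc(Cl)cc3Cl)C2=O)c1OC` gives 16300 nM, a clearly higher number than either. Compound 3 therefore shares the low end of this small set with compound 1.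

Compound 4 `COc1cc(/C=C2\CCC/C(=C\c3cccc(OC)c3OC)C2=O)ccc1O` comes from compound 3 by one small edit: hydrogen in place of methyl on an oxygen on an aromatic ring, or methoxy to hydroxy (hydrogen in place of methyl on an oxygen on an aromatic ring).

Among the compounds with values here, no measured step makes this exact swap, so the evidence is indirect. The closest is a 1.1-fold lower number from compound 1 to compound 3 (0.04 log units; within the scatter), which adds the very methoxy whose methyl leaves in compound 4, and that addition stayed within the scatter. Within the data shown here, the only step beyond the scatter is a 2.3-fold higher number from compound 1 to compound 2 (0.37 log units; beyond the scatter), and it was modest even though it replaced a whole substituted aromatic ring. From the compounds shown here alone, a far smaller edit is thus expected to produce little or no real shift in this assay, though a new hydroxy is untested here and the range must stay wide. The expected size is a 1.2-fold lower number from compound 3 to compound 4 (0.07 log units; within the scatter), which would lie within the scatter. For compound 4 the estimated value is 5500 nM, with an expected range from 2300 nM to 13000 nM.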

Compound 4, half-maximal inhibitory concentration: 8600 nM
Compound 4: middle estimate off by 1.6-fold (0.19 log units), on the low side; low and high end bracket the measured number.
By their numbers in this assay, from the lowest: compounds 3, 1, 4 and 2 (each within the scatter of the next, the first and the last beyond it).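

In this assay, the first direct test of this change at this oxygen gives a 1.3-fold higher number from compound 3 to compound 4 (0.13 log units; within the scatter), so removing the methyl to leave a hydroxy produces no real shift here. The comparison with the compound that has only hydrogen on that aromatic carbon points the same way: adding a hydroxy gives a 1.2-fold higher number from compound 1 to compound 4 (0.09 log units; within the scatter), and adding a methoxy had given a 1.1-fold lower number from compound 1 to compound 3 (0.04 log units; within the scatter), so neither group can be told apart from hydrogen at this carbon. The whole-ring swap gives a 1.9-fold lower number from compound 2 to compound 4 (0.28 log units; within the scatter), which also stays within the scatter, so compound 4 cannot be separated from compound 2, even though compound 1 can be, with a 2.3-fold higher number from compound 1 to compound 2 (0.37 log units; beyond the scatter).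

No accompanying measurement offers an explanation for why this oxygen substituent makes so little difference to the cytotoxicity reading. The compounds shown leave open whether a larger or different group at this place, such as an ethoxy, a longer chain on the oxygen or an amine in place of the hydroxy, would move the number beyond the scatter.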